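This account rests on a few compounds, and the source may have more. Where it says the series, first, only, none or still open, it means among the compounds named here.

The measured compounds stand as follows. Compound 1 `COc1cc(/C=N/NC(=O)COc2cccc3ccccc23)cc(OC)c1OC` gives >= 20 ug/mL in an ADME assay on HEL cells (Homo sapiens) for cytotoxicity (on this read-out higher numbers stand for lower toxicity in this test and lower numbers for higher toxicity in this test), which is a limit of the assay and not a number. Compound 3 `COc1ccc(/C=N/NC(=O)COc2cccc3ccccc23)cc1OC` gives >= 20 ug/mL in this assay, likewise a limit. Compound 2 `O=C(COc1cccc2ccccc12)N/N=C/c1ccc(O)cc1` gives 20 ug/mL in this assay.

Among the measured compounds shown here, compound 2 therefore stands as the only number among the three values; the other two sit at the limit of >= 20 ug/mL in this assay, at which 2 of the 3 values shown sit. For the measured compounds named here, the one step among measured compounds, a step that the two limits leave unreadable from compound 1 to compound 3, cannot be read in size, since both ends are limits.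

Compound 4 `O=C(COc1cccc2ccccc12)N/N=C/c1cccc(O)c1` is the next compound. It differs from compound 2 by 3-hydroxyphenyl in place of 4-hydroxyphenyl on a carbon with a double bond to nitrogen. Going by the values given here, no measured step bears on this change: the single step that exists concerns a methoxy group, and its size is unreadable. Among the compounds with values here, nothing among the measured compounds points to a shift in either direction, so the expected step of no change at the digits printed from compound 2 to compound 4 (within the scatter) is none beyond the scatter. Compound 4 is expected to give 20 ug/mL in this assay, with a range from 10 ug/mL to 40 ug/mL, while a limit rather than a number remains a fair possibility.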

Compound 4, minimum cytotoxic concentration: 100 ug/mL
The estimate for compound 4 lay 5.0-fold (0.70 log units) below the measured number; the whole stated range lies below it.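

The change to 3-hydroxyphenyl in place of 4-hydroxyphenyl on a carbon with a double bond to nitrogen gives a 5.0-fold higher number from compound 2 to compound 4 (0.70 log units; beyond the scatter) in this assay, so the result in this test is sensitive to where the hydroxyl stands on this ring. Compound 2 and compound 4 have the same atoms, joined differently, and the same counts of hydrogen-bond donors and acceptors in the changed group, so the rearrangement alone accounts for this move toward lower toxicity in this test. Nothing measured among these compounds gives a reason for the step.

As far as these compounds go, whether an amine or a carboxylic acid in place of the hydroxyl on the 3-hydroxyphenyl group would keep or lose the higher number remains open. So does the effect of changes elsewhere on the shared core of compound 4.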